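A few compounds are considered here, and "the series" means these few. Any claim that something is new, unique, unknown or untested is made for them only; others in the source may bear on it.

Compound 2 `COc1cc(N)c(Cl)cc1C(=O)N[C@H]1CCN(CC2CCN(C(=O)CC(C)C)CC2)C[C@H]1OC` gives the lowest number of the three measured compounds in an assay on COS-7 cells for displacement of a labelled ligand from 5-hydroxytryptamine receptor 4 (Homo sapiens), read by scintillation counting, with a stated time of 30 min; a higher number here means a weaker inhibitor, a lower number a stronger inhibitor: compound 2 gives 78 nM. Compound 1 `CCCC(=O)N1CCC(CN2CC[C@H](NC(=O)c3cc(Cl)c(N)cc3OC)[C@H](OC)C2)CC1` gives 178 nM, and compound 3 `CCC(=S)N1CCC(CN2CC[C@H](NC(=O)c3cc(Cl)c(N)cc3OC)[C@H](OC)C2)CC1` gives 593 nM. The step is a 2.3-fold lower number from compound 1 to compound 2 (0.36 log units; beyond the scatter), and the step is a 7.6-fold higher number from compound 2 to compound 3 (0.88 log units; beyond the scatter); between the other pair the step is a 3.3-fold higher number from compound 1 to compound 3 (0.52 log units; beyond the scatter).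

Compound 4 `COc1cc(N)c(Cl)cc1C(=O)N[C@H]1CCN(CC2CCN(C(=O)N(C)C)CC2)C[C@H]1OC` differs from compound 2 by dimethylamino in place of isobutyl on a carbonyl carbon. Among the measured compounds shown here, no measured step makes exactly this exchange. For the measured compounds named here, the steps that bear on it are those that alter the same acyl group on the ring nitrogen: the step from compound 1 to compound 2, where a larger branched chain gave a lower number, and the steps to compound 3, where a smaller group with sulfur in place of oxygen gave a higher number. Both point the same way: a smaller group on that carbonyl carbon has so far meant a higher number. Dimethylamino is smaller than isobutyl, so a modest rise in this assay is expected, of about a 3.2-fold higher number from compound 2 to compound 4 (0.51 log units; beyond the scatter). Compound 4 is therefore estimated at 250 nM, with a range from 100 nM to 800 nM.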

Compound 4, half-maximal inhibitory concentration: 52 nM
Beside the measured number, compound 4's estimate is 4.8-fold (0.68 log units) above it; measured number below the stated range.
By their numbers in this assay, from the lowest: compounds 4 and 2 (each within the scatter of the next); then compound 1; then compound 3.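

Read in this assay the exchange of isobutyl for dimethylamino, on a carbonyl carbon whose other neighbour is an amide-type nitrogen in a ring, leaves compound 2 and compound 4 within the usual scatter of each other (a 1.5-fold lower number from compound 2 to compound 4 (0.18 log units; within the scatter)). The same dimethylamino group also stands clearly apart from the propyl of compound 1 (a 3.4-fold lower number from compound 1 to compound 4 (0.53 log units; beyond the scatter)) and from the sulfur-bearing group of compound 3 (an 11-fold lower number from compound 3 to compound 4 (1.06 log units; beyond the scatter)), and this last step is the largest among the four compounds. Heavy-atom count alone therefore does not order the numbers at this position: compound 3 fits the idea that a smaller group gives a higher number, whereas compound 4 goes against it, since dimethylamino has fewer heavy atoms than isobutyl and the two are not separated in this assay.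

Nothing shown gives a reason why the dimethylamino group is tolerated here. The compounds also leave open whether diethylamino or methoxy on the same carbonyl carbon would stay with compound 2 and compound 4, or fall back towards compound 1.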